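The source may report more compounds than this note shows. Statements on the series, on what has been measured and on what is new or still open speak of the compounds shown alone.

In a functional assay on HCT-116 cells (Homo sapiens) for cytotoxicity, read by sulforhodamine B assay, with a stated time of 48 h (on this read-out lower numbers stand for stronger inhibition and higher numbers for weaker inhibition), compound 1 (`COc1cc(/C=C/C(=O)/C=C/c2cccs2)ccc1OCc1cn(CCOc2cc(=O)oc3ccccc23)nn1`) gives 9290 nM and compound 2 (`COc1ccc(/C=C/C(=O)/C=C/c2ccc(OCc3cn(CCCOc4cc(=O)oc5ccccc45)nn3)c(OC)c2)cc1OC`) gives 11000 nM, two values within the usual scatter of each other. Compound 3 (`COc1cc(/C=C/C(=O)/C=C/c2ccco2)ccc1OCc1cn(CCOc2cc(=O)oc3ccccc23)nn1`) carries furan-2-yl in place of thiophen-2-yl on a double-bonded chain carbon bound to a double-bonded chain carbon. Among the compounds with values here, no measured pair shows this exchange, so the data give no direct guide, and no change beyond the scatter is expected in either direction. The estimated change is a 1.0-fold lower number from compound 1 to compound 3 (0.01 log units; within the scatter). The estimated value for compound 3 is 9000 nM, with an expected range of 4000 nM to 20000 nM.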

Compound 3, half-maximal inhibitory concentration: 9180 nM
For compound 3 the middle estimate is 1.0-fold (0.01 log units) below the measured one; the measured number falls inside the stated range.
By their numbers in this assay, from the lowest: compounds 3, 1 and 2 (each within the scatter of the next).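

In this assay, within the data shown here, furan-2-yl in place of thiophen-2-yl gives a 1.0-fold lower number from compound 1 to compound 3 (0.01 log units; within the scatter), the first direct reading of any exchange at this position. On a double-bonded chain carbon bound to a double-bonded chain carbon, this read-out does not separate the two five-membered aromatic rings. No measurement on hand bears on this result.

Going by these compounds, it remains open whether a phenyl ring, an amine-bearing ring or a carboxylic acid at this place would read alike. On these data alone, the same exchange on the chain and ring pattern of compound 2 also remains open.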